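A Methoxy-to-Hydroxymethyl Swap on a Weak Phosphodiesterase Inhibitor

The compounds below may be only part of what the source reports. "The series", "measured", "known", "first", "only" and "open" are said of these compounds alone.

Of the compounds shown here, two have been measured in an assay on isolated protein for inhibition of high affinity 3',5'-cyclic-AMP phosphodiesterase 7A (Homo sapiens), read by cAMP accumulation, with a stated time of 20 min; on this read-out lower numbers stand for stronger inhibition and higher numbers for weaker inhibition. Compound 1 `COCCNc1ccnc2c1nc(-c1ccco1)n2C1CCCC1` gives 119000 nM, and compound 2 `COCCNc1nccc2c1nc(-c1ccco1)n2C1CCCC1` gives 192000 nM; the two numbers lie within the scatter of each other, so compound 2 stands beside compound 1 rather than apart from it. Compound 3 `OCCCNc1nccc2c1nc(-c1ccco1)n2C1CCCC1` differs from compound 2 by hydroxymethyl in place of methoxy on a saturated chain carbon, two bonds along the chain from a nitrogen on an aromatic ring. Among the compounds with values here, no measured pair shows what such a change does here, so the step is expected to stay within the scatter, in no set direction: a 1.0-fold higher number from compound 2 to compound 3 (0.02 log units; within the scatter). Compound 3 is thus expected to give 200000 nM, within 70000 nM to 600000 nM.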

Compound 3, half-maximal inhibitory concentration: > 200000 nM
Compound 3 gave a limit, no number; the forecaster's own chance of this, stated with the estimate: 25%; the middle value sits exactly at the limit.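

In this assay compound 3 gives > 200000 nM, which is a limit of the assay and not a number. Hydroxymethyl in place of methoxy at this place on the chain gives only an at least 1.0-fold higher number from compound 2 to compound 3 (0.01 log units; that floor lies within the scatter), so the change shows no stronger inhibition. Its true size stays unread because the reading stops at the limit: the limit of > 200000 nM in this assay, at which 1 of the 3 values shown sits.

On these data alone, whether an amine, a carboxylic acid or a longer chain at this place would bring stronger inhibition remains open. So does whether the same change would read alike on the core of compound 1.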